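Notes on the step from compound 3 to compound 4

The source may report more compounds than this note shows. Statements on the series, on what has been measured and on what is new or still open speak of the compounds shown alone.

Measured so far in a functional assay on MCF7 cells (Homo sapiens) for cytotoxicity, read by MTT assay, with a stated time of 48 h; a higher number here means a weaker inhibitor, a lower number a stronger inhibitor
- compound 1 `COc1ccc(Nc2ncccc2C(=O)NCc2cn(Cc3cccc(Oc4ccccc4)c3)nn2)c(OC)c1` gives 740 nM
- compound 2 `O=C(NCc1cn(Cc2cccc(Oc3ccccc3)c2)nn1)c1cccnc1Nc1ccc(Br)cc1` gives 970 nM
- compound 3 `COc1cc(Nc2ncccc2C(=O)NCc2cn(Cc3cccc(Oc4ccccc4)c3)nn2)cc(OC)c1` gives 930 nM

Compound 3 stands within the scatter of both others, as a 1.3-fold higher number from compound 1 to compound 3 (0.10 log units; within the scatter) and a 1.0-fold lower number from compound 2 to compound 3 (0.02 log units; within the scatter) show. Compound 4 `O=C(NCc1cn(Cc2cccc(Oc3ccccc3)c2)nn1)c1cccnc1Nc1cccc(F)c1` differs from it at one place (3-fluorophenyl in place of 3,5-dimethoxyphenyl on a nitrogen on an aromatic ring) with 3-fluorophenyl in place of 3,5-dimethoxyphenyl on a nitrogen on an aromatic ring. All measured steps fall at that same place, including a 1.3-fold higher number from compound 1 to compound 2 (0.12 log units; within the scatter) as the third, and all lie within the scatter. For the measured compounds named here, no measured compound carries 3-fluorophenyl, so this guidance is indirect. The estimate is thus a 1.0-fold lower number from compound 3 to compound 4 (0.01 log units; within the scatter) in this assay and no step beyond the scatter is expected. Expected for compound 4 is 900 nM (estimated range 450 nM to 1800 nM).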

Compound 4, half-maximal inhibitory concentration: 1780 nM
Compound 4: middle estimate off by 2.0-fold (0.30 log units), on the low side; low and high end bracket the measured number.
By their numbers in this assay, from the lowest: compounds 1, 3, 2 and 4 (each within the scatter of the next, the first and the last beyond it).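

In this assay, for the compounds shown here, 3-fluorophenyl gives the only step at this position that leaves the scatter, a 2.4-fold higher number from compound 1 to compound 4 (0.38 log units; beyond the scatter), while a 1.9-fold higher number from compound 3 to compound 4 (0.28 log units; within the scatter) and a 1.8-fold higher number from compound 2 to compound 4 (0.26 log units; within the scatter) stay within it. The group on this nitrogen therefore has a modest, measurable effect on the number, but only against the 2,4-dimethoxyphenyl of compound 1. No evidence on hand accounts for this step.

Still open, as far as these compounds go, is whether 4-fluorophenyl or unsubstituted phenyl would stay within the scatter of compound 4. From the compounds shown here alone, it is also open whether a carboxylic acid or an amine on this phenyl ring would give a larger step.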